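The source may hold more compounds than are shown below. What is called first, only, known or untested is meant among the compounds shown, and "the series" means these compounds.

The measured compounds:
compound 1, `COc1ccc(-c2c(-c3cc(OC)c(OC)c(OC)c3)ssc2=S)cc1`, which gives 2270 nM in a functional assay on HT-1080 cells (Homo sapiens) for antiproliferative activity, read by MTT assay, with a stated time of 72 h; a lower number here means a stronger inhibitor, a higher number a weaker inhibitor
compound 2, `COc1ccc(-c2c(-c3cc(OC)c(OC)c(OC)c3)ssc2=S)cc1[N+](=O)[O-]`, which gives 3550 nM in this assay
compound 3, `COc1ccc(-c2c(-c3cc(OC)c(OC)c(OC)c3)ssc2=O)cc1`, for which this assay reports only a limit, > 100000 nM

The change from compound 1 to compound 2 is nitro in place of hydrogen on an aromatic carbon. Its size is a 1.6-fold higher number from compound 1 to compound 2 (0.19 log units; within the scatter). How the core of compound 3 differs from that of compound 1 is not broken down here. Compound 4, `COc1ccc(-c2c(-c3cc(OC)c(OC)c(OC)c3)ssc2=O)cc1[N+](=O)[O-]`, has not yet been measured; it carries the same change as above, (nitro in place of hydrogen on an aromatic carbon), made on the core of compound 3. Since the value of compound 3 is a limit (the limit of > 100000 nM in this assay, at which 1 of the 3 values shown sits), and the same change did little in the pair already measured, compound 4 is expected to sit near that limit as well. Compound 4 is estimated at 150000 nM, between 50000 nM and 500000 nM. The step this estimate means is expected to be a step that the limit leaves unreadable from compound 3 to compound 4.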

Compound 4, half-maximal inhibitory concentration: > 100000 nM
Compound 4 gave a limit, no number (the forecaster's own chance of this, stated with the estimate: 80%); the middle value does not contradict the limit.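

Compound 3 and compound 4 each give only a limit in this assay, so no step between them can be read: the limit of > 100000 nM in this assay, at which 2 of the 4 values shown sit.

The compounds shown leave open what nitro in place of hydrogen on an aromatic carbon does on the core of compound 3.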